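Removing One Fluoro Group from Compound 2

This account rests on a few compounds, and the source may have more. Where it says the series, first, only, none or still open, it means among the compounds named here.

For the measured compounds named here, in a functional assay on OVCAR-5 cells (Homo sapiens) for inhibition, read by CCK-8 assay, with a stated time of 72 h, tested at 1 uM (on this read-out higher numbers stand for more inhibition of growth at the one concentration tested and lower numbers for less inhibition of growth), compound 2 (`CN(C)C(=O)c1cc2cnc(Nc3ccc(NC(=O)C4(C(=O)Nc5ccccc5F)CC4)cc3)nc2n1C1CCCC1`) gives 58%, the highest of the three numbers so far. Compound 1 (`CN(C)C(=O)c1cc2cnc(Nc3ccc(N)cn3)nc2n1C1CCCC1`) gives 12.3% and compound 3 (`Nc1ccc(NC(=O)C2(C(=O)Nc3ccc(F)cc3)CC2)cc1F`) gives 6.7%, both lower than compound 2 by more than the scatter. Compound 4 (`CN(C)C(=O)c1cc2cnc(Nc3ccc(NC(=O)C4(C(=O)Nc5ccccc5)CC4)cc3)nc2n1C1CCCC1`) differs from compound 2 in one place: hydrogen in place of fluoro on an aromatic carbon. Hydrogen replaces fluoro on an aromatic carbon, ortho to a large group, so 2-fluorophenyl becomes phenyl. Going by the values given here, no measured pair shows this change on its own, so the estimate starts from compound 2 at 58%. The estimated step of a number 6 percentage points lower from compound 2 to compound 4 (within the scatter) is slightly downward and within the scatter. For compound 4 the expected value is 52%, with an estimated range of 36% to 66%.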

Compound 4, percent growth inhibition at one concentration: 52.1%
Compound 4: middle estimate off by 0.1 percentage points, on the low side, within the range that was stated.
By their numbers in this assay, from the lowest: compounds 3 and 1 (each within the scatter of the next); then compounds 4 and 2 (each within the scatter of the next).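

In this assay, for the compounds shown here, taking away the fluoro group gives a number 5.9 percentage points lower from compound 2 to compound 4 (within the scatter), the first measured pair that shows this change on its own. On this read-out, compound 2 and compound 4 cannot be told apart, so the fluoro group at this place on the aromatic ring is not needed for the growth inhibition seen at the one concentration tested. No measurement shown explains this result. Still open, on these data alone, is whether a chloro, methoxy or amino group in the same place would leave the number unmoved, and whether compound 2 and compound 4 also match at other concentrations.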